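This account rests on a few compounds, and the source may have more. Where it says the series, first, only, none or still open, it means among the compounds named here.

Working notes on the series. The compounds share one core and differ in the group on the amine nitrogen of the side chain. In a physicochemical assay for solubility, at pH 4 (on this read-out higher numbers stand for higher solubility and lower numbers for lower solubility), compound 1 `CC[C@H]1OC(=O)[C@H](C)[C@@H](O)[C@H](C)[C@@H](O[C@@H]2O[C@H](C)C[C@H](N(C)C)[C@H]2OCCCNC(=O)CNc2ccnc3ccccc23)[C@](C)(O)C[C@@H](C)CN(C)[C@H](C)[C@@H](O)[C@]1(C)O` sits at the limit of the assay, giving > 10000 ug/mL. Compound 3 `CC[C@H]1OC(=O)[C@H](C)[C@@H](O)[C@H](C)[C@@H](O[C@@H]2O[C@H](C)C[C@H](N(C)C)[C@H]2OCCCNc2ccnc3cc(Cl)ccc23)[C@](C)(O)C[C@@H](C)CN(C)[C@H](C)[C@@H](O)[C@]1(C)O` sits at the same limit in this assay, with > 10000 ug/mL. Compound 2 `CC[C@H]1OC(=O)[C@H](C)[C@@H](O[C@H]2C[C@@](C)(OC)[C@@H](O)[C@H](C)O2)[C@H](C)[C@@H](O[C@@H]2O[C@H](C)C[C@H](N(C)C)[C@H]2OCCCNc2ccnc3ccccc23)[C@](C)(O)C[C@@H](C)CN(C)[C@H](C)[C@@H](O)[C@]1(C)O` likewise is reported in this assay only as a limit, > 10000 ug/mL. Within the data shown here, with the limit of > 10000 ug/mL in this assay, at which 3 of the 3 values shown sit, no step between measured compounds can be sized. Compound 4 `CC[C@H]1OC(=O)[C@H](C)[C@@H](O[C@H]2C[C@@](C)(OC)[C@@H](O)[C@H](C)O2)[C@H](C)[C@@H](O[C@@H]2O[C@H](C)C[C@H](N(C)C)[C@H]2OCCCNCc2ccc3ccccc3n2)[C@](C)(O)C[C@@H](C)CN(C)[C@H](C)[C@@H](O)[C@]1(C)O` carries (quinolin-2-yl)methyl in place of quinolin-4-yl on an amine nitrogen. Among the measured compounds shown here, no measured step covers this change, and in this assay the step from compound 2 to compound 4 is expected to lie within the scatter, estimated as a number no higher from compound 2 to compound 4 (the limit leaves the size open). Compound 4 is therefore expected at the limit again, estimated at 10000 ug/mL with a range of 4000 ug/mL to 10000 ug/mL.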

Compound 4, solubility: > 10000 ug/mL
Compound 4 gave a limit, no number; the forecaster's own chance of this, stated with the estimate: 80%; the middle value sits exactly at the limit.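

No step can be read between compound 2 and compound 4, because both sit at the same limit: the limit of > 10000 ug/mL in this assay, at which 4 of the 4 values shown sit.

Going by these compounds, whether (quinolin-2-yl)methyl and quinolin-4-yl on the amine nitrogen differ at all in this assay stays open.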